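This account rests on a few compounds, and the source may have more. Where it says the series, first, only, none or still open, it means among the compounds named here.

Values in a functional assay on HeLa cells (Homo sapiens) for inhibition, read by sulforhodamine B assay; on this read-out higher numbers stand for weaker inhibition and lower numbers for stronger inhibition:
- compound 1 `O=C1C=C(N2CCC2)C(=O)c2c1nc1n2[C@H]2OC[C@@H](O)[C@H]2OC1`: > 16000 nM, a limit of the assay
- compound 2 `COc1ccccc1NC1=CC(=O)c2nc3n(c2C1=O)[C@H]1OC[C@@H](O)[C@H]1OC3`: 2950 nM
- compound 3 `COc1cccc(NC2=CC(=O)c3nc4n(c3C2=O)[C@H]2OC[C@@H](O)[C@H]2OC4)c1`: 4280 nM

Compound 3 stands level with its nearest neighbour, a 1.5-fold higher number from compound 2 to compound 3 (0.16 log units; within the scatter), and clear of the limit, an at least 3.7-fold lower number from compound 1 to compound 3 (0.57 log units; beyond the scatter). Compound 4 `O=C1C=C(Nc2cccc(Cl)c2)C(=O)c2c1nc1n2[C@H]2OC[C@@H](O)[C@H]2OC1` carries chloro in place of methoxy on an aromatic carbon, meta to a large group: chloro in place of methoxy on an aromatic carbon. Within the data shown here, no measured step exchanges this substituent for another. The closest, a 1.5-fold higher number from compound 2 to compound 3 (0.16 log units; within the scatter), only shifts the methoxy and stays within the scatter, while compound 4 keeps the arylamino group that accompanied an at least 3.7-fold lower number from compound 1 to compound 3 (0.57 log units; beyond the scatter). No change beyond the scatter is therefore expected in this assay. The expected step is a 1.2-fold lower number from compound 3 to compound 4 (0.09 log units; within the scatter). Compound 4 is estimated at 3500 nM, with an expected range of 1500 nM to 9000 nM.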

Compound 4, half-maximal inhibitory concentration: 6040 nM
For compound 4 the middle estimate is 1.7-fold (0.24 log units) below the measured one; the measured number falls inside the stated range.
By their numbers in this assay, from the lowest: compounds 2, 3 and 4 (each within the scatter of the next, the first and the last beyond it). At a limit, above all of these: compound 1.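

In this assay, among these compounds, the first exchange of the substituent itself, chloro in place of methoxy, stays within the scatter (a 1.4-fold higher number from compound 3 to compound 4 (0.15 log units; within the scatter)). Yet 3-chlorophenyl in place of 2-methoxyphenyl on the amine nitrogen gives a modest step beyond it (a 2.0-fold higher number from compound 2 to compound 4 (0.31 log units; beyond the scatter)), although neither the shift of methoxy nor the exchange for chloro alone leaves the scatter. The gap to the azetidin-1-yl compound remains only a bound (an at least 2.6-fold lower number from compound 1 to compound 4 (0.42 log units; beyond the scatter)), as compound 1 stands at a limit: the limit of > 16000 nM in this assay, at which 1 of the 4 values shown sits.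

On these data alone, whether another group here, such as an amine, a carboxylic acid or trifluoromethyl, would move the number beyond the scatter stays open. So does whether chloro would match methoxy on the ring carbon it occupies in compound 2.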